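A few compounds are considered here, and "the series" means these few. Any claim that something is new, unique, unknown or untested is made for them only; others in the source may bear on it.

Compounds measured so far, with their values in an ADME assay on HCT-116 cells (Homo sapiens) for cytotoxicity, read by CellTiter-Glo, with a stated time of 72 h; on this read-out lower numbers stand for stronger inhibition and higher numbers for weaker inhibition:

Compound 1, `Cc1cc(C)c(S(=O)(=O)N2CCC(C3OCC(C)CO3)CC2)c(C)c1`, gives > 5000 nM, which is a limit of the assay and not a number.
Compound 2, `CC1CCN(C2CCN(S(=O)(=O)c3cccc(-c4ccc(F)cc4)c3)CC2)CC1`, gives > 5000 nM, again only a limit.
Compound 3, `Cc1cc(C)c(S(=O)(=O)N2CCC(N3CCC(O)CC3)CC2)c(C)c1`, gives > 5000 nM, again only a limit.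

Compound 3 therefore stands where every measured value sits, at the limit of > 5000 nM in this assay, at which 3 of the 3 values shown sit. Within the data shown here, the one step among measured compounds, a step that the two limits leave unreadable from compound 1 to compound 3, cannot be read because both ends are limits. Compound 4, `Cc1cc(C)c(S(=O)(=O)N2CCC(N3CCC(CCO)CC3)CC2)c(C)c1`, differs from compound 3 by 2-hydroxyethyl in place of hydroxy on a saturated ring carbon. Among the measured compounds shown here, no measured step involves a change of this kind, so nothing among the measured compounds points to a shift in either direction. Compound 4 is expected to remain at the limit as well, with an estimated value of 10000 nM, ranging from 5000 nM to 50000 nM. The expected step that the limit leaves unreadable from compound 3 to compound 4 is estimated as none beyond the scatter.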

Compound 4, half-maximal inhibitory concentration: > 5000 nM
Compound 4 ended at the assay's limit; the forecaster's own chance of this, stated with the estimate: 85%; the middle value lies beyond the limit too.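

Neither the step from compound 3 to compound 4 nor the step from compound 1 to compound 4 can be read, as both ends of each are limits: the limit of > 5000 nM in this assay, at which 4 of the 4 values shown sit.

The compounds shown leave open whether 2-hydroxyethyl in place of hydroxy changes the read-out at all.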